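Triazolyl in Place of Carboxyethyl on the Amide Nitrogen

The source may hold more compounds than are shown below. What is called first, only, known or untested is meant among the compounds shown, and "the series" means these compounds.

Of the compounds shown here, two sharing one core have been measured in a functional assay on the whole organism for inhibition, with Rattus norvegicus as the target, with a stated time of 30 min, at a dose of 1 mg/kg by the intravenous route; a higher number here means more inhibition at the dose given (going by the name of the read-out), a lower number less inhibition. Compound 1 `O=C(Nc1nnn[nH]1)c1cc(=O)c2ccccc2o1` gives 100%. Compound 2 `O=C(O)CCNC(=O)c1cc(=O)c2ccccc2o1` gives 0%, the lowest of the two numbers; its nearest neighbour is compound 1, which stands far above it, the gap being beyond the scatter.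

Compound 3 `O=C(Nc1nc[nH]n1)c1cc(=O)c2ccccc2o1` has not yet been measured. It differs from compound 2 at one place: 1H-1,2,4-triazol-3-yl in place of 2-carboxyethyl on an amide-type nitrogen. Among the compounds with values here, the only measured step that bears on this change is a number 100 percentage points lower from compound 1 to compound 2 (beyond the scatter), where a five-membered aromatic ring with hetero atoms on the amide-type nitrogen gave way to an open chain carrying a carboxylic acid. That step was large. The group entering in compound 3 is again a five-membered aromatic ring with hetero atoms in the same place, so a large rise in this assay is expected for compound 3, although a ring of a different kind need not reach the level of compound 1. The expected step is a number 70 percentage points higher from compound 2 to compound 3 (beyond the scatter). Compound 3 is therefore estimated at 70%, with a likely range from 20% to 100%.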

Compound 3, a percentage reported as inhibition, in the whole organism at one dose (the size of the read-out at that dose, not a potency): 0%
The estimate for compound 3 lay 70 percentage points above the measured number; measured number below the stated range.
By their numbers in this assay, from the lowest: compounds 2 and 3 (each within the scatter of the next); then compound 1.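

In this assay, a five-membered aromatic ring on the amide-type nitrogen does not by itself bring inhibition at the dose given: placing 1H-1,2,4-triazol-3-yl where 2-carboxyethyl stood gives no change at the digits printed from compound 2 to compound 3 (within the scatter) in this comparison. The exchange of one ring for the other is far more telling, with a number 100 percentage points lower from compound 1 to compound 3 (beyond the scatter) on going from 1H-tetrazol-5-yl to 1H-1,2,4-triazol-3-yl while the rest of the molecule stays the same. So among these three compounds, the high reading goes with the 1H-tetrazol-5-yl group alone and not with five-membered aromatic rings as a class, and no measurement at hand accounts for the sharp difference between the two rings.

The compounds shown leave open whether inhibition returns with other ring groups on this nitrogen, such as an imidazolyl, a pyrazolyl or a 1H-1,2,3-triazolyl group. They also do not settle whether an open chain can work here at all, for instance a carboxymethyl group, a longer chain ending in a carboxylic acid, or a chain ending in an amine.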